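The compounds below may be only part of what the source reports. "The series", "measured", "known", "first", "only" and "open" are said of these compounds alone.

Working notes on the shared core in an ADME assay on BaF3 cells (Mus musculus) for cytotoxicity; on this read-out lower numbers stand for an effect already at smaller amounts and higher numbers for an effect only at larger amounts of compound. Compound 1 `FC(F)(F)Oc1ccc(Nc2cc(-c3ccc4[nH]ccc4c3)ncn2)cc1` carries a 1H-indol-5-yl group on the core. In this assay compound 1 gives > 10000 nM, which is a limit of the assay and not a number. Compound 2 `NS(=O)(=O)c1cccc(-c2cc(Nc3ccc(OC(F)(F)F)cc3)ncn2)c1` is the second measured member. In this assay compound 2 gives > 10000 nM, again a limit rather than a number. Compound 3 `CCn1cc2c(Nc3ccc(OC(F)(F)F)cc3)ncnc2n1` is the third measured member. In this assay compound 3 gives > 10000 nM, also a limit. For the measured compounds named here, compound 1 therefore stands where the other two stand, at the limit of > 10000 nM in this assay, at which 3 of the 3 values shown sit, so no order among the three can be read and no step between measured compounds is available.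

The unmeasured compound 4 `FC(F)(F)Oc1ccc(Nc2cc(-c3cccc4[nH]ccc34)ncn2)cc1` differs from compound 1 in one place: 1H-indol-4-yl in place of 1H-indol-5-yl on an aromatic carbon. With compound 1 at a limit, no direction for this change can be drawn from the numbers.

The step from compound 1 to compound 4 is expected to be a step that the limit leaves unreadable from compound 1 to compound 4, none beyond the scatter, because every measured member sits at the limit of > 10000 nM in this assay, at which 3 of the 3 values shown sit. Compound 4 is estimated at 15000 nM, with a range from 5000 nM to 50000 nM, and most likely reported only as a limit.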

Compound 4, half-maximal effective concentration: 3790 nM
Beside the measured number, compound 4's estimate is 4.0-fold (0.60 log units) above it; the measured number lies below the stated range.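

For the compounds shown here, exchanging 1H-indol-5-yl for 1H-indol-4-yl on this aromatic carbon of the shared core gives an at least 2.6-fold lower number from compound 1 to compound 4 (0.42 log units; beyond the scatter) in this assay, the first step that can be read beyond the scatter. Going by these compounds alone, the two groups have the same atoms and the same counts of rings and hydrogen-bond donors, so the read-out at this position responds to how the group is joined to the core, not only to which atoms it brings, and the earlier compounds could not show this. Compound 4 is the only member shown that carries a number and not a limit, so the full size of the step stays unknown and the other members cannot be ordered against one another: the limit of > 10000 nM in this assay, at which 3 of the 4 values shown sit.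

From the compounds shown here alone, whether the lower number in this assay belongs to 1H-indol-4-yl alone, or would also follow from a smaller group at the same aromatic carbon, such as a primary amine or a carboxylic acid, stays open. The compounds shown also leave open whether the same exchange would give a step of this kind with a group other than the trifluoromethoxy-bearing aniline on the shared core.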